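Dropping a side chain on a weak antiproliferative scaffold

The source may report more compounds than this note shows. Statements on the series, on what has been measured and on what is new or still open speak of the compounds shown alone.

Compound 2 `CC/C=C/Cn1c(Cc2cc(OC)c(OC)c(OC)c2)nc2c(N)ncnc21` and compound 1 `CC[C@H](C)Cn1c(Cc2cc(OC)c(OC)c(OC)c2)nc2c(N)nc(F)nc21` share a core that carries a trimethoxybenzyl arm. In a functional assay on MCF7 cells (Homo sapiens) for antiproliferative activity (on this read-out lower numbers stand for stronger inhibition and higher numbers for weaker inhibition), compound 2 gives 46800 nM, and compound 1 gives 43700 nM; the two numbers lie within the usual scatter of each other, so neither compound can be called the more active one, and both sit at weak inhibition. Compound 3 `COc1cc(Cc2nc3c(N)ncnc3n2C)cc(OC)c1OC` keeps that core but differs from compound 2 in one respect: hydrogen in place of but-1-en-1-yl on a saturated chain carbon bound to an aromatic nitrogen. Among the measured compounds shown here, no measured pair shows what such a trimming does here, so the expectation rests only on the weak numbers of compound 2 and compound 1. Because compound 2 already gives 46800 nM, the step of a 1.4-fold higher number from compound 2 to compound 3 (0.14 log units; within the scatter) is expected to be small and, if anything, toward weaker inhibition. Compound 3 is thus estimated at 65000 nM in this assay, within a range from 20000 nM to 200000 nM.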

Compound 3, half-maximal inhibitory concentration: 70800 nM
Compound 3: the middle estimate sits 1.1-fold (0.04 log units) below what was measured; low and high end bracket the measured number.
By their numbers in this assay, from the lowest: compounds 1, 2 and 3 (each within the scatter of the next).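

In this assay, among the compounds shown here, the step of a 1.5-fold higher number from compound 2 to compound 3 (0.18 log units; within the scatter) gives the first direct reading of this position, where hydrogen takes the place of but-1-en-1-yl on a saturated chain carbon bound to an aromatic nitrogen. The step lies within the scatter, so cutting away this chain of 4 carbons and its double bond leaves no difference that can be told from repeat noise, and inhibition remains weak in this one pair. Nothing measured alongside these compounds offers an explanation for this result.

As far as these compounds go, it remains open whether a chain ending in an amine or a carboxylic acid at this place would move the number beyond the scatter. The separate contribution of the fluorine on the core of compound 1 is also unresolved.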